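This account rests on a few compounds, and the source may have more. Where it says the series, first, only, none or still open, it means among the compounds named here.

Among the compounds with values here, compound 2 `O=C(CCC(=O)OCCCCCCSc1ccc([N+](=O)[O-])c2nonc12)Nc1cccc(Cl)c1` stands at the top of the numbers so far: in an assay on isolated protein for inhibition of glutathione S-transferase Mu 2 (Homo sapiens), with a stated time of 10 min (a higher number here means a weaker inhibitor, a lower number a stronger inhibitor), compound 2 gives 1100 nM, the highest of the three values measured. Compound 1 `O=C(O)CCC(=O)OCCCCCCSc1ccc([N+](=O)[O-])c2nonc12` gives 160 nM in this assay, and compound 3 `CN(C)CCNC(=O)CCC(=O)OCCCCCCSc1ccc([N+](=O)[O-])c2nonc12` gives 160 nM; between those two there is no change at the digits printed from compound 1 to compound 3 (within the scatter). The two steps that reach compound 2 are larger: a 6.9-fold higher number from compound 1 to compound 2 (0.84 log units; beyond the scatter) and, going the other way, a 6.9-fold lower number from compound 2 to compound 3 (0.84 log units; beyond the scatter).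

Compound 4 `O=C(CCC(=O)OCCCCCCSc1ccc([N+](=O)[O-])c2nonc12)NCCN1CCCC1` is the next member of the series. Its difference from compound 2 is 2-(pyrrolidin-1-yl)ethyl in place of 3-chlorophenyl on an amide-type nitrogen.

The step that bears on this is a 6.9-fold lower number from compound 2 to compound 3 (0.84 log units; beyond the scatter), where the 3-chlorophenyl group was also exchanged for a two-carbon chain carrying an amino group on an amide-type nitrogen. The same exchange, with the 2-(pyrrolidin-1-yl)ethyl group in place of the 2-(dimethylamino)ethyl group, is expected to give a step of about the same size and in the same direction, so a clearly lower number is expected. The estimated step is therefore a 5.5-fold lower number from compound 2 to compound 4 (0.74 log units; beyond the scatter). Compound 4 is expected to give 200 nM in this assay, within a range from 90 nM to 500 nM.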

Compound 4, half-maximal inhibitory concentration: 200 nM
Compound 4: the middle estimate sits on the measured number at the digits printed, within the range that was stated.
By their numbers in this assay, from the lowest: compounds 1, 3 and 4 (each within the scatter of the next); then compound 2.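

In this assay, a second amine-bearing chain on the amide-type nitrogen also gives a step beyond the scatter, a 5.5-fold lower number from compound 2 to compound 4 (0.74 log units; beyond the scatter), so this result no longer rests on the 2-(dimethylamino)ethyl group alone. Changing the terminal amine gives a 1.3-fold higher number from compound 3 to compound 4 (0.10 log units; within the scatter), and the comparison with the hydroxy compound reads a 1.3-fold higher number from compound 1 to compound 4 (0.10 log units; within the scatter), so among the three compounds the exchange of dimethylamino for pyrrolidin-1-yl and the replacement of hydroxy by either amine-bearing chain cannot be told apart, while compound 2 stands apart from all of them. Nothing measured here gives a reason for this pattern.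

Still open, going by these compounds, is whether the terminal amine matters at all, which a plain butyl amide would test, or whether a longer chain before the amine, or a morpholine in its place, holds the same level. An unsubstituted phenyl amide would show whether the chlorine contributes to the higher number of compound 2.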